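A few compounds are considered here, and "the series" means these few. Any claim that something is new, unique, unknown or untested is made for them only; others in the source may bear on it.

Measured compounds:
compound 1, `COc1ccc(-n2nc(C(N)=O)nc2-c2cc(OC)c(OC)c(OC)c2)cc1`: 40%
compound 2, `COc1ccc(NC(=O)c2nc(-c3cc(OC)c(OC)c(OC)c3)n(-c3ccc(OC)cc3)n2)cc1`: 39%

Of the compounds shown here, two have so far been measured in a functional assay on the whole organism for inhibition, with Rattus norvegicus as the target, read by paw edema, with stated times of 30 min and 1 h, at a dose of 0.28 mmol/kg by the oral route; a lower number here means less inhibition, a higher number more inhibition at the dose given (going by the name of the read-out). Compound 1 `COc1ccc(-n2nc(C(N)=O)nc2-c2cc(OC)c(OC)c(OC)c2)cc1` gives 40%. Compound 2 `COc1ccc(NC(=O)c2nc(-c3cc(OC)c(OC)c(OC)c3)n(-c3ccc(OC)cc3)n2)cc1`, which carries a 4-methoxyphenyl in place of hydrogen on the amide-type nitrogen, gives 39%. These two numbers lie within the usual scatter of each other, so compound 1 is not separated from compound 2 by the data; the step between them is a number 1 percentage points lower from compound 1 to compound 2 (within the scatter).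

Compound 3 `COc1ccc(-n2nc(C(=O)Nc3ccc(C(F)(F)F)cc3)nc2-c2cc(OC)c(OC)c(OC)c2)cc1` has not yet been measured. It differs from compound 1 as follows: 4-(trifluoromethyl)phenyl in place of hydrogen on an amide-type nitrogen. For the measured compounds named here, only one measured step bears on this change, namely the one in which another aryl group, 4-methoxyphenyl, entered at the same amide-type nitrogen; that step was a number 1 percentage points lower from compound 1 to compound 2 (within the scatter). Going by the values given here, with that as the sole guide, no step beyond the scatter is expected in this assay, in either direction. Compound 3 is therefore estimated at 40%, with a range from 26% to 54%, which means an expected step of no change at the digits printed from compound 1 to compound 3 (within the scatter).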

Compound 3, a percentage reported as inhibition, in the whole organism at one dose (the size of the read-out at that dose, not a potency): 48%
Beside the measured number, compound 3's estimate is 8 percentage points below it, and the stated range covers the measured number.
By their numbers in this assay, from the lowest: compounds 2, 1 and 3 (each within the scatter of the next).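

In this assay the entry of 4-(trifluoromethyl)phenyl in place of hydrogen on the amide-type nitrogen gives a number 8 percentage points higher from compound 1 to compound 3 (within the scatter) and thus adds a second aryl group at this position that the read-out does not separate from the plain amide. The exchange of methoxy for trifluoromethyl on the aromatic carbon of that ring gives a number 9 percentage points higher from compound 2 to compound 3 (within the scatter) and shows that these two groups, which differ in their atoms, are not told apart here either. So far, then, the three compounds form one group at this single dose, and nothing measured here accounts for the small differences among their numbers.

The compounds shown leave open whether a group of another kind on this nitrogen, such as a methyl group, a longer alkyl chain or a chain ending in an amine, would stand apart from the plain amide. They also leave open what a carboxylic acid or a chlorine atom would do in place of the methoxy or trifluoromethyl on the aromatic carbon of that ring.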